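The compounds below may be only part of what the source reports. "The series", "measured", "known", "first", "only" and "open" are said of these compounds alone.

Compound 1 `Nc1ncnn2c([C@@H]3O[C@H](CO)[C@@H](O)[C@H]3O)cc(C#CC3CC3)c12`, compound 2 `Nc1ncnn2c([C@@H]3O[C@H](CO)[C@@H](O)[C@H]3O)cc(C#Cc3ccc(F)cc3)c12` and compound 3 `Nc1ncnn2c([C@@H]3O[C@H](CO)[C@@H](O)[C@H]3O)cc(-c3ccc(Cl)cc3)c12` have been measured.

In a functional assay on HCT-116 cells (Homo sapiens) for antiproliferative activity, with a stated time of 72 h (a lower number here means a stronger inhibitor, a higher number a weaker inhibitor), compound 1 gives 50 nM. For compound 2 this assay reports only its limit, > 100000 nM. Compound 3 gives 59300 nM. Compound 1 thus holds the lower of the two numbers on record, with the third value being a limit.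

Compound 4 `Nc1ncnn2c([C@@H]3O[C@H](CO)[C@@H](O)[C@H]3O)cc(-c3ccccc3F)c12` differs from compound 1 in one place: 2-fluorophenyl in place of 2-cyclopropylethynyl on an aromatic carbon. Among the measured compounds shown here, two measured steps bear on this change, an at least 2000-fold higher number from compound 1 to compound 2 (3.30 log units; beyond the scatter) and a 1200-fold higher number from compound 1 to compound 3 (3.07 log units; beyond the scatter); in each an aromatic ring replaced the cyclopropylethynyl group and the loss was large. A similar large upward step is therefore expected, a 1000-fold higher number from compound 1 to compound 4 (3.00 log units; beyond the scatter). Compound 4 is estimated at 50000 nM, in a range from 8000 nM to 300000 nM.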

Compound 4, half-maximal inhibitory concentration: > 100000 nM
Compound 4: no number, only a limit; the forecaster's own chance of this, stated with the estimate: 35%; middle value at least 2.0-fold (0.30 log units) from the limit.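

In this assay a directly attached phenyl ring carrying fluorine instead of chlorine also loses the activity of compound 1, with an at least 2000-fold higher number from compound 1 to compound 4 (3.30 log units; beyond the scatter), so the loss is not confined to the 4-chlorophenyl group. The other step, an at least 1.6-fold higher number from compound 3 to compound 4 (0.22 log units; that floor lies within the scatter), does not set these two compounds apart. The step between compound 2 and compound 4 cannot be read, as both values are limits: the limit of > 100000 nM in this assay, at which 2 of the 4 values shown sit.

From the compounds shown here alone, it remains open whether an ethyl group or an aminomethyl group on the triple bond would retain the activity of compound 1. Going by these compounds, it also remains open whether a cyclopropyl group attached directly to the aromatic carbon would do so.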